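The source may hold more compounds than are shown below. What is called first, only, known or untested is meant among the compounds shown, and "the series" means these compounds.

In an assay on lysate for inhibition of phosphatidylcholine:ceramide cholinephosphotransferase 2 (Homo sapiens), read by HPLC, with stated times of 30 min and 2 h (a lower number here means a stronger inhibitor, a higher number a weaker inhibitor), compound 1 `O=C(Nc1cccnc1)c1ccccc1OCc1ccccc1` gives 3200 nM, and compound 2 `O=C(Nc1cccnc1)c1ccccc1OCc1cccc(F)c1` gives 1600 nM. Within the data shown here, the one measured step, a 2.0-fold lower number from compound 1 to compound 2 (0.30 log units; within the scatter), moves the number no further than repeated measurement of the same compound would, so the two values stand together rather than in any order, and compound 2 has no neighbour that is clearly apart from it. Compound 3 `O=C(Nc1cccnc1)c1ccccc1OCc1cc(Cl)ccc1Cl` is not yet measured; it differs from compound 2 in one place: 2,5-dichlorophenyl in place of 3-fluorophenyl on a saturated chain carbon bound to an oxygen on an aromatic ring. Among the measured compounds shown here, only the step of a 2.0-fold lower number from compound 1 to compound 2 (0.30 log units; within the scatter) bears on this, and only loosely: it adds a single fluorine and stays within the scatter, while nothing measured exchanges the whole ring for a 2,5-dichlorophenyl. The expected step is therefore small, a 1.3-fold lower number from compound 2 to compound 3 (0.12 log units; within the scatter), with no direction that should exceed the scatter. For compound 3 the estimate is 1200 nM, expected to fall between 400 nM and 4000 nM.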

Compound 3, half-maximal inhibitory concentration: 990 nM
For compound 3 the middle estimate is 1.2-fold (0.08 log units) above the measured one; measured number inside the range.
By their numbers in this assay, from the lowest: compounds 3, 2 and 1 (each within the scatter of the next, the first and the last beyond it).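

In this assay, putting 2,5-dichlorophenyl in place of phenyl on a saturated chain carbon bound to an oxygen on an aromatic ring gives a 3.2-fold lower number from compound 1 to compound 3 (0.51 log units; beyond the scatter), the first step shown that clears the scatter, though only modestly. Putting the same group in place of 3-fluorophenyl gives a 1.6-fold lower number from compound 2 to compound 3 (0.21 log units; within the scatter), so compound 2 and compound 3 stand together, and the position tolerates two chlorine atoms on this ring with no loss of inhibition. Nothing measured here accounts for these numbers.

The compounds shown leave open whether a single chlorine would serve as well as two. They also leave open how a ring bearing an amine or a nitrile, or a longer chain in place of the saturated chain carbon, would behave at this position.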